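One More Isopropyl on the Amine Nitrogen

The source may hold more compounds than are shown below. What is called first, only, known or untested is meant among the compounds shown, and "the series" means these compounds.

In a functional assay on SK-BR-3 cells (Homo sapiens) for antiproliferative activity (a lower number here means a stronger inhibitor, a higher number a weaker inhibitor), compound 1 `CCCNCCCOc1ccc2cc(NC(=O)c3ccc(O)c(CC=C(C)C)c3)c(=O)oc2c1C` gives 990 nM and compound 2 `CC(C)=CCc1cc(C(=O)Nc2cc3ccc(OCCCN(C)C(C)C)c(C)c3oc2=O)ccc1O` gives 570 nM, so compound 2 holds the lowest number of the two, though only within the scatter. Compound 3 `CC(C)=CCc1cc(C(=O)Nc2cc3ccc(OCCCN(C(C)C)C(C)C)c(C)c3oc2=O)ccc1O` differs from compound 2 by isopropyl in place of methyl on an amine nitrogen. For the measured compounds named here, the one measured step that also alters this amine is a 1.7-fold lower number from compound 1 to compound 2 (0.24 log units; within the scatter). With so small a precedent, no step beyond the scatter is expected, and the expected step is a 1.1-fold higher number from compound 2 to compound 3 (0.02 log units; within the scatter). For compound 3 the estimated value is 600 nM, with an expected range of 250 nM to 1400 nM.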

Compound 3, half-maximal inhibitory concentration: 1600 nM
Compound 3: middle estimate off by 2.7-fold (0.43 log units), on the low side; the whole stated range lies below it.
By their numbers in this assay, from the lowest: compounds 2, 1 and 3 (each within the scatter of the next, the first and the last beyond it).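

In this assay, for the compounds shown here, this amine nitrogen proves sensitive to its substituents: isopropyl in place of methyl gives the first step beyond the scatter (a 2.8-fold higher number from compound 2 to compound 3 (0.45 log units; beyond the scatter)). Diisopropylamino in place of propylamino, by contrast, stays within the scatter (a 1.6-fold higher number from compound 1 to compound 3 (0.21 log units; within the scatter)), so only compound 2 stands apart from compound 3. No available evidence explains the rise.

From the compounds shown here alone, whether a larger group such as tert-butyl on this nitrogen would raise the number further remains open. So does whether a ring amine such as piperidine or morpholine would sit nearer compound 2 or compound 3.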